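This account rests on a few compounds, and the source may have more. Where it says the series, first, only, none or still open, it means among the compounds named here.

Compounds measured so far:
compound 1, `Oc1ccc(-c2cc(-c3ccccc3)nc(-c3ccccc3Cl)c2)cc1`: 2800 nM
compound 2, `Oc1cccc(-c2cc(-c3ccccc3)nc(-c3ccc(Cl)cc3)c2)c1`: 11200 nM

Both numbers come from a functional assay on DU-145 cells (Homo sapiens) for cytotoxicity, read by CCK-8 assay and cell counting, with a stated time of 2 days; on this read-out higher numbers stand for weaker inhibition and lower numbers for stronger inhibition. Compound 2 gives the higher of the two; the gap from compound 1 to compound 2 lies beyond the scatter. The two compounds differ in more than one place, so the gap cannot be attached to any single change.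

Compound 3, `Oc1ccc(-c2cc(-c3ccccc3)nc(-c3ccc(Cl)cc3)c2)cc1`, has not been measured. Against compound 2 the change is 4-hydroxyphenyl in place of 3-hydroxyphenyl on an aromatic carbon; the 4-chlorophenyl group of compound 2 is kept, so compound 3 pairs the hydroxyphenyl arrangement of compound 1 with the chlorophenyl arrangement of compound 2. Among the measured compounds shown here, no measured pair isolates this change. Because compound 1, which carries the same 4-hydroxyphenyl group, gives 2800 nM, a number below that of compound 2 is expected, and the step is estimated as a 2.2-fold lower number from compound 2 to compound 3 (0.35 log units; beyond the scatter), a modest move whose size against the scatter is uncertain. For compound 3 the value in this assay is estimated at 5000 nM, with a range from 1500 nM to 16000 nM.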

Compound 3, half-maximal inhibitory concentration: 7270 nM
Estimate against measurement, compound 3: 1.5-fold (0.16 log units) below; low and high end bracket the measured number.
By their numbers in this assay, from the lowest: compound 1; then compounds 3 and 2 (each within the scatter of the next).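

In this assay, 4-hydroxyphenyl in place of 3-hydroxyphenyl, on the aromatic carbon opposite the ring nitrogen, gives a 1.5-fold lower number from compound 2 to compound 3 (0.19 log units; within the scatter), so with the 4-chlorophenyl group kept, this change of hydroxyl placement cannot be told apart from the scatter. With the 4-hydroxyphenyl group kept, 4-chlorophenyl in place of 2-chlorophenyl gives a 2.6-fold higher number from compound 1 to compound 3 (0.41 log units; beyond the scatter), so among these three compounds, the gap between compound 1 and compound 2, which could not earlier be attached to any single change, now has a one-place step beyond the scatter on the chlorophenyl side and none on the hydroxyphenyl side. Nothing at hand speaks to the cause of either step.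

The pairing of 3-hydroxyphenyl with 2-chlorophenyl lies outside the compounds shown, so it remains open whether hydroxyl placement stays within the scatter alongside 2-chlorophenyl, and 3-chlorophenyl is also absent from the comparison. Also open, from the compounds shown here alone, is how an amine, a methoxy group or a carboxylic acid in place of the hydroxyl would read, and what any substituent on the phenyl group would do.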